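Cytotoxicity notes: nitrile for amine on the benzyl arm

This account rests on a few compounds, and the source may have more. Where it says the series, first, only, none or still open, it means among the compounds named here.

Measured compounds:
Compound 1 `COC(=O)c1ccc(NCc2cncn2Cc2ccc(N)cc2)cc1-c1ccccc1`: > 10000 nM
Compound 2 `COc1ccc(NCc2cncn2Cc2ccc(-c3ccccc3)cc2N)cc1-c1ccccc1`: > 1000 nM
Compound 3 `O=C(OC1CCCCC1)c1ccc(NCc2cncn2Cc2ccc(-c3ccccc3)cc2)cc1-c1ccccc1`: > 10000 nM

In a toxicity assay on NIH3T3 cells (Mus musculus) for cytotoxicity, read by resazurin assay (a lower number here means that less compound is needed, a higher number that more compound is needed for the effect), compound 1 reaches only a limit, > 10000 nM. Compound 2 likewise gives only a limit in this assay, > 1000 nM. Compound 3 also stops at a limit, > 10000 nM. None of the three values is a number; two values sit at the limit of > 10000 nM in this assay, at which 2 of the 3 values shown sit, and one at the limit of > 1000 nM in this assay, at which 1 of the 3 values shown sits, so compound 1 stands with the others at the edge of the assay.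

Compound 4 `COC(=O)c1ccc(NCc2cncn2Cc2ccccc2C#N)cc1-c1ccccc1` is not yet measured. It differs from compound 1 by 2-cyanophenyl in place of 4-aminophenyl on a saturated chain carbon bound to an aromatic nitrogen. Within the data shown here, no step between measured compounds is known, and every value shown is a limit, so no direction beyond the scatter is expected for a step that the limit leaves unreadable from compound 1 to compound 4. Compound 4 is estimated at 15000 nM in this assay, within 5000 nM to 50000 nM, most likely again reported only as a limit.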

Compound 4, half-maximal effective concentration: 25000 nM
Beside the measured number, compound 4's estimate is 1.7-fold (0.22 log units) below it, within the range that was stated.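

Among these compounds, no step from compound 1 to compound 4 can be read in this assay: the value of compound 1, > 10000 nM, is only a limit. The compounds shown leave open whether 2-cyanobenzyl in place of 4-aminobenzyl changes the value at all.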